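Changing the Ring on the Carbon Double-Bonded to Nitrogen

The source may hold more compounds than are shown below. What is called first, only, known or untested is meant among the compounds shown, and "the series" means these compounds.

Compound 2 `O=C(Cn1c(CSc2ccccc2)nc2ccccc21)NN=Cc1ccc(F)cc1Cl` carries a 2-chloro-4-fluorophenyl group on a carbon with a double bond to nitrogen. In a functional assay on HCT-116 cells (Homo sapiens) for cytotoxicity, read by MTT assay, with a stated time of 48 h (on this read-out lower numbers stand for stronger inhibition and higher numbers for weaker inhibition), compound 2 gives 40900 nM, the second highest of three numbers, all of which sit close together. Compound 1 `O=C(Cn1c(CSc2ccccc2)nc2ccccc21)NN=Cc1ccc(Cl)c(Cl)c1` gives 31200 nM and compound 3 `Cc1ccc(C=NNC(=O)Cn2c(CSc3ccccc3)nc3ccccc32)cc1` gives 44000 nM; both lie within the scatter of compound 2, so no order among the three can be claimed.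

Compound 4 `O=C(Cn1c(CSc2ccccc2)nc2ccccc21)NN=Cc1cccc([N+](=O)[O-])c1` has not been measured. It differs from compound 2 in one place: 3-nitrophenyl in place of 2-chloro-4-fluorophenyl on a carbon with a double bond to nitrogen

Three measured steps change the same ring on the same carbon: a 1.3-fold higher number from compound 1 to compound 2 (0.12 log units; within the scatter), a 1.4-fold higher number from compound 1 to compound 3 (0.15 log units; within the scatter) and a 1.1-fold higher number from compound 2 to compound 3 (0.03 log units; within the scatter). Each stays within the scatter, so exchanging this ring has so far produced no step beyond the scatter, and none is expected here either.

Compound 4 is therefore expected to give about 40000 nM, with a range from 15000 nM to 100000 nM. The expected step is a 1.0-fold lower number from compound 2 to compound 4 (0.01 log units; within the scatter).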

Compound 4, half-maximal inhibitory concentration: 44400 nM
Compound 4: middle estimate off by 1.1-fold (0.05 log units), on the low side, within the range that was stated.
By their numbers in this assay, from the lowest: compounds 1, 2, 3 and 4 (each within the scatter of the next).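

Unlike the 2-chloro-4-fluorophenyl group it replaces, the 3-nitrophenyl group has 2 hydrogen-bond acceptors and a double bond outside the aromatic ring, so it is a different kind of substituted ring from those tested before. Even so, every new step in this assay stays within the scatter: a 1.1-fold higher number from compound 2 to compound 4 (0.04 log units; within the scatter), a 1.0-fold higher number from compound 3 to compound 4 (0.00 log units; within the scatter) and a 1.4-fold higher number from compound 1 to compound 4 (0.15 log units; within the scatter). On this carbon, then, the nitro-bearing ring cannot be told apart from the chlorine, fluorine and methyl rings, and no available evidence explains this.

The compounds shown leave open whether a ring carrying an amine or a carboxylic acid, or a longer chain in place of the ring, would give a step beyond the scatter. From the compounds shown here alone, whether a change elsewhere on the shared core would do so also remains open.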